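The source may hold more compounds than are shown below. What is called first, only, known or untested is meant among the compounds shown, and "the series" means these compounds.

Of the compounds shown here, two have been measured in a functional assay on A549 cells (Homo sapiens) for inhibition, read by sulforhodamine B assay, with a stated time of 48 h; a higher number here means a weaker inhibitor of growth, a lower number a stronger inhibitor of growth. Compound 1 `CC(=O)/C(=C\c1c(-c2ccccc2)[nH]c2ccccc12)S(=O)(=O)c1ccccc1` gives 7200 nM, and compound 2 `N#C/C(=C\c1c(-c2ccccc2)[nH]c2ccccc12)S(=O)(=O)c1ccccc1` gives 3700 nM. Among the compounds with values here, the only step between them, a 1.9-fold lower number from compound 1 to compound 2 (0.29 log units; within the scatter), exchanges an acetyl for a cyano on the double-bonded chain carbon and lies within the scatter, so the two numbers cannot be told apart. Compound 2 therefore holds the lower of the two numbers without standing apart from compound 1.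

Compound 3 `N#C/C(=C\c1c(-c2ccccc2)[nH]c2ccccc12)C(=O)c1ccccc1` has not yet been measured. It differs from compound 2 in a single place: benzoyl in place of phenylsulfonyl on a double-bonded chain carbon bound to a double-bonded chain carbon and a triple-bonded carbon. Within the data shown here, no measured step touches a sulfonyl-for-carbonyl exchange; the one known step replaces acetyl with cyano and was itself within the scatter. The data thus give no basis for expecting a shift beyond the scatter in this assay in either direction, and the estimate simply stays close to compound 2 with a wide range.

Compound 3 is expected to give about 4000 nM in this assay, with a range from 1300 nM to 12000 nM. This corresponds to an expected step of a 1.1-fold higher number from compound 2 to compound 3 (0.03 log units; within the scatter).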

Compound 3, concentration for 50% growth inhibition: 7600 nM
For compound 3 the middle estimate is 1.9-fold (0.28 log units) below the measured one; low and high end bracket the measured number.
By their numbers in this assay, from the lowest: compounds 2, 1 and 3 (each within the scatter of the next, the first and the last beyond it).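

Within the data shown here, at the double-bonded chain carbon bound to a double-bonded chain carbon and a triple-bonded carbon, this assay gives the first step in this set that lies beyond the scatter, with a 2.1-fold higher number from compound 2 to compound 3 (0.31 log units; beyond the scatter) when benzoyl takes the place of phenylsulfonyl. With the nitrile kept in place, this position therefore responds to the group it carries, and within this pair the phenylsulfonyl compound is the stronger inhibitor of growth, although the step is modest and only just clears the scatter. Nothing shown here accounts for the difference, so it cannot be assigned to the sulfur, to the second oxygen or to any other part of the exchanged group. 

It remains open whether the exchange of phenylsulfonyl for benzoyl would have the same effect with acetyl in place of the nitrile, since the compounds shown test it only with the nitrile present. From the compounds shown here alone, it is also open how other groups at this place would compare, such as a carboxylic acid, a methyl ester or an amide, and whether a group of any of these kinds would move the number further in either direction.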